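Predicting a shifted nitro-difluorophenyl analogue in a leukaemia cell assay

The compounds below may be only part of what the source reports. "The series", "measured", "known", "first", "only" and "open" are said of these compounds alone.

Measured so far in a functional assay on CCRF-CEM cells (Homo sapiens) for cytotoxicity, in the absence of a further agent; on this read-out lower numbers stand for stronger inhibition and higher numbers for weaker inhibition:
- compound 1, `COC(=O)c1ccc(CN(CCCc2c(N)nc(N)nc2O)c2cc(F)c(F)cc2[N+](=O)[O-])cc1`, gives 55000 nM
- compound 2, `COC(=O)c1ccc(CN(CCCc2c(N)nc(N)nc2O)c2ccc([N+](=O)[O-])c(F)c2F)cc1`, gives 45000 nM
- compound 3, `CC(C)(C)OC(=O)CCC(Nc1ccc(CN(CCCc2c(N)nc(N)nc2O)c2ccc([N+](=O)[O-])c(F)c2F)cc1)C(=O)OC(C)(C)C`, gives 36000 nM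

All three numbers sit close together, and each step between them falls within the usual scatter, so none of these compounds can be called stronger or weaker than another. Compound 1 and compound 2 share a core and differ only in one ring: 4,5-difluoro-2-nitrophenyl in place of 2,3-difluoro-4-nitrophenyl on an amine nitrogen. That swap gave a 1.2-fold higher number from compound 2 to compound 1 (0.09 log units; within the scatter). Compound 3 carries a larger core than compound 2; the difference between the two cores is not broken down here.

Compound 4, `CC(C)(C)OC(=O)CCC(Nc1ccc(CN(CCCc2c(N)nc(N)nc2O)c2cc(F)c(F)cc2[N+](=O)[O-])cc1)C(=O)OC(C)(C)C`, has not yet been tested. It relates to compound 3 exactly as compound 1 relates to compound 2: 4,5-difluoro-2-nitrophenyl in place of 2,3-difluoro-4-nitrophenyl on an amine nitrogen. Because a 1.2-fold higher number from compound 2 to compound 1 (0.09 log units; within the scatter), the same change on the core of compound 3 is expected to move the number only a little. The step from compound 3 to compound 4 is estimated as a 1.2-fold higher number from compound 3 to compound 4 (0.08 log units; within the scatter). Compound 4 is therefore expected to give about 43000 nM in this assay, most likely between 20000 nM and 90000 nM.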

Compound 4, half-maximal inhibitory concentration: 3400 nM
The estimate for compound 4 lay 13-fold (1.10 log units) above the measured number, outside the stated range (below it).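

In this assay, putting 4,5-difluoro-2-nitrophenyl in place of 2,3-difluoro-4-nitrophenyl on the amine nitrogen gave an 11-fold lower number from compound 3 to compound 4 (1.02 log units; beyond the scatter). Set beside the earlier result, the same ring change behaved differently on the two cores: the same change on two cores in this assay, a 1.2-fold higher number (0.09 log units; within the scatter) from compound 2 to compound 1 and an 11-fold lower number (1.02 log units; beyond the scatter) from compound 3 to compound 4, 13-fold (1.11 log units) apart, beyond the scatter of two such steps

So in this series, a step read on one core could not simply be carried over to the other, and the outcome of this change depended on the core that carried it; this rests on only one pair of compounds per core, and it does not show why the two cores differ or how the change would behave on any third core.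

The compounds shown leave open which part of the larger core of compound 3 goes with the difference. A matched pair with a free carboxylic acid in place of the tert-butyl esters, or with a longer chain to the amine nitrogen, could show whether the difference persists.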